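The source may hold more compounds than are shown below. What is called first, only, known or untested is meant among the compounds shown, and "the series" means these compounds.

Of the compounds shown here, two have numbers so far in a functional assay on DU-145 cells (Homo sapiens) for inhibition, read by trypan blue exclusion, with a stated time of 72 h; on this read-out higher numbers stand for weaker inhibition and lower numbers for stronger inhibition. Compound 1 `Cn1c(=O)c(S(=O)(=O)c2ccc(F)cc2)cc2cnc(Nc3ccc4occc4c3)nc21` gives 5000 nM, and compound 2 `COc1ccc(Nc2ncc3cc(S(=O)(=O)c4ccc(C)cc4)c(=O)n(C)c3n2)cc1` gives 100000 nM. Compound 1 therefore holds the lower of the two numbers, and the gap between them lies beyond the usual scatter of repeated measurements. The two compounds differ in more than one place, so this gap cannot be tied to any single group.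

Compound 3 `Cn1c(=O)c(S(=O)(=O)c2ccc(F)cc2)cc2cnc(Nc3ccc4cc[nH]c4c3)nc21` has not yet been measured. It keeps the core of compound 1 and alters one group: 1H-indol-6-yl in place of 1-benzofuran-5-yl on a nitrogen on an aromatic ring. In plain terms, 1H-indol-6-yl stands in place of 1-benzofuran-5-yl on a nitrogen on an aromatic ring. Among the compounds with values here, no measured pair isolates a single change like this one, so the data offer no direct guide to its size. The expectation in this assay is therefore cautious, with no step beyond the scatter and no firm direction. The estimated change is a 1.7-fold lower number from compound 1 to compound 3 (0.22 log units; within the scatter). For compound 3 the expected value is 3000 nM, with an estimated range from 500 nM to 20000 nM.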

Compound 3, half-maximal inhibitory concentration: 10000 nM
For compound 3 the middle estimate is 3.3-fold (0.52 log units) below the measured one, within the range that was stated.
By their numbers in this assay, from the lowest: compounds 1 and 3 (each within the scatter of the next); then compound 2.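

Within the data shown here, with 1-benzofuran-5-yl replaced by 1H-indol-6-yl on a nitrogen on an aromatic ring, this assay gives a 2.0-fold higher number from compound 1 to compound 3 (0.30 log units; within the scatter), the first comparison here that isolates a single place. The two groups have the same ring types and the same count of heavy atoms, but they differ in their hetero atom, their point of attachment and their hydrogen-bond donors and acceptors, and this read-out does not separate them. No measurement here explains why the two groups read alike.

Compound 2 differs from compound 1 in more than one place, so its much higher number still cannot be assigned to the group on this nitrogen or to the group on the sulfonyl. From the compounds shown here alone, it also remains open whether a group of a different kind on this nitrogen, such as a phenyl ring carrying a carboxylic acid or a basic amine, or a short alkyl chain, would move the number beyond the usual scatter of repeated measurements.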